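The source may hold more compounds than are shown below. What is called first, only, known or untested is meant among the compounds shown, and "the series" means these compounds.

Measured so far in an ADME assay on Vero cells (Chlorocebus sabaeus) for cytotoxicity, with a stated time of 72 h; a higher number here means a weaker inhibitor, a lower number a stronger inhibitor:

- Compound 1 (`CCOC(=O)c1cc(/C=C/c2ccccc2)on1`) gives "not determined" (no result reported)
- Compound 2 (`CCOC(=O)c1cc(/C=C/c2cccc(C(C)C)c2)on1`) gives a limit, not a number: > 128000 nM
- Compound 3 (`CCOC(=O)c1cc(/C=C/c2cccc([N+](=O)[O-])c2)on1`) gives a limit, not a number: > 128000 nM

Compound 1 has no reading of its own, so the only anchor for it is the assay limit shared by the other two compounds (the limit of > 128000 nM in this assay, at which 2 of the 3 values shown sit). Compound 4 (`CCOC(=O)c1cc(/C=C/c2ccc(OCc3ccccc3)cc2)on1`) is still unmeasured. It differs from compound 1 by benzyloxy in place of hydrogen on an aromatic carbon, para to a large group (benzyloxy in place of hydrogen on an aromatic carbon).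

Within the data shown here, only one measured step bears on this change, and it replaces isopropyl with nitro (a step that the two limits leave unreadable from compound 2 to compound 3). Its size cannot be read, so it offers no magnitude to carry over. Resting on that step, no step of definite size is expected in this assay between compound 1 and compound 4. Any number that does appear is expected on the stronger side of the limit. In this assay the estimated value for compound 4 is 110000 nM (expected range 45000 nM to 128000 nM).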

Compound 4, half-maximal inhibitory concentration: > 128000 nM
Compound 4 ended at the assay's limit; the forecaster's own chance of this, stated with the estimate: 70%; middle value at least 1.1-fold (0.06 log units) from the limit.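

In this assay compound 4 gives > 128000 nM, a limit and not a number. Among these compounds, no step from compound 1 to compound 4 can be read. The compounds shown leave open at what concentration any of them reaches half-maximal inhibition, with the readings stopping at a shared limit: the limit of > 128000 nM in this assay, at which 3 of the 4 values shown sit.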